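Thiosemicarbazone and amide variants on a shared chlorobenzothiazole core

The compounds below may be only part of what the source reports. "The series", "measured", "known", "first", "only" and "open" are said of these compounds alone.

Measured compounds:
compound 1, `Fc1ccc(/C=N/NC(=S)Nc2nc3ccc(Cl)cc3s2)cc1`, 100 mg/kg
compound 2, `CC(C)(C)NCC(=O)Nc1nc2ccc(Cl)cc2s1`, 300 mg/kg

Of the compounds shown here, two have been measured in a functional assay on the whole organism with Mus musculus as the target, with a stated time of 4 h; a lower number here means that less compound is needed, a higher number that more compound is needed for the effect. Compound 1 gives 100 mg/kg, the lower of the two numbers. Compound 2 gives 300 mg/kg, a higher number, and the gap between compound 1 and compound 2 is beyond the scatter. The two differ in more than one place, so nothing more than the two values themselves can be said of that pair.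

Compound 3, `O=[N+]([O-])c1ccc(/C=N/NC(=S)Nc2nc3ccc(Cl)cc3s2)cc1`, has not yet been measured in this assay. It differs from compound 1 at one place: nitro in place of fluoro on an aromatic carbon. Going by the values given here, no pair of measured compounds shows this change, and compound 2 gives no guidance on it, since it carries a different side chain altogether.

Among the compounds with values here, with no step of this kind among the measured compounds, the expectation for compound 3 is a step of no change at the digits printed from compound 1 to compound 3 (within the scatter), that is, no change beyond the scatter in either direction. The minimum effective dose of compound 3 in this assay is therefore estimated at 100 mg/kg, with a range from 30 mg/kg to 300 mg/kg.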

Compound 3, minimum effective dose: 300 mg/kg
Compound 3: middle estimate off by 3.0-fold (0.48 log units), on the low side; the measured number falls inside the stated range.
By their numbers in this assay, from the lowest: compound 1; then compounds 2 and 3 (each within the scatter of the next).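

The aromatic carbon para to a large group is now shown not to be neutral in the thiosemicarbazone side chain of compound 1: in this assay nitro in place of fluoro gives a 3.0-fold higher number from compound 1 to compound 3 (0.48 log units; beyond the scatter) and is a modest step, beyond the scatter. Going by these compounds alone, this is the first reading of a single change, whereas the earlier comparison differed in more than one place and could not be assigned to any one part of the structures. The exchange of one fluorine for a group of three heavy atoms with two hydrogen-bond acceptors therefore moves the dose in the upward direction, but no measurement available here explains that shift.

A single step cannot separate the effect of losing fluoro from that of gaining nitro, and a plain hydrogen, a chlorine, a methoxy group or an amine on the same carbon would help to tell these apart. From the compounds shown here alone, it also remains open whether the same exchange at another carbon of this ring, or on a different side chain attached to the shared core, would give a step of similar size or direction.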